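A Methoxy-to-Methyl Swap Under a Cell Toxicity Readout

This account rests on a few compounds, and the source may have more. Where it says the series, first, only, none or still open, it means among the compounds named here.

This study looks at how tolerant mouse fibroblast cells are toward a small family of compounds built around one shared core. The measure used is a toxicity assay on NIH3T3 cells (Mus musculus) for cytotoxicity, read by resazurin assay; on this read-out lower numbers stand for an effect already at smaller amounts and higher numbers for an effect only at larger amounts of compound. Compound 1, `c1ccc(-c2ccc(Cn3cncc3CNc3ccccc3-c3ccccc3)cc2)cc1`, gives a result that is only a limit, > 10000 nM, in this assay. Compound 3, `CC(C)c1cccc(NCc2cncn2Cc2ccccc2)c1`, also gives only a limit, > 1000 nM, in this assay. Compound 2, `COC(=O)c1ccc(NCc2cncn2Cc2ccc(OC)cc2)cc1-c1ccccc1`, has no single number at all: its entry in this assay reads "not determined" (no result reported). The two other values that exist in the set are both limits rather than measured points, one sitting at the limit of > 1000 nM in this assay, at which 1 of the 3 values shown sits, and one at the limit of > 10000 nM in this assay, at which 1 of the 3 values shown sits.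

The step followed here leads from compound 2 to compound 4, `COC(=O)c1ccc(NCc2cncn2Cc2ccccc2C)cc1-c1ccccc1`, which is not yet measured. The change is 2-methylphenyl in place of 4-methoxyphenyl on a saturated chain carbon bound to an aromatic nitrogen. No measured step between any two compounds of this set exists, so there is no direct guide to how large a shift this swap might cause in this assay. Given that every result so far is a limit, the expectation is that the step brings no change beyond the scatter and that compound 4 also shows an effect only at large amounts. Compound 4 is therefore estimated at 15000 nM, with a range from 3000 nM to 60000 nM.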

Compound 4, half-maximal effective concentration: 10000 nM
Compound 4: the middle estimate sits 1.5-fold (0.18 log units) above what was measured; measured number inside the range.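

No step can be read here: compound 2 has no reported result in this assay and so offers compound 4 no partner for comparison. The compounds shown leave open whether the change from 4-methoxyphenyl to 2-methylphenyl shifts the toxicity result at all. Nothing shown accounts for the result of compound 4.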